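A few compounds are considered here, and "the series" means these few. Any claim that something is new, unique, unknown or untested is made for them only; others in the source may bear on it.

Measured so far:
compound 1, `Cc1ccc2[nH]c(C(=O)N[C@H]3CCN(C(=O)c4cccnc4)C[C@@H]3C(=O)NCCN(C)C)cc2c1`, 91%
compound 2, `Cc1ccc2[nH]c(C(=O)N[C@H]3CN(S(=O)(=O)c4ccccc4)C[C@H]3C(=O)NCCN(C)C)cc2c1`, 72%
compound 3, `Cc1csc(C(=O)N[C@H]2CN(S(=O)(=O)c3ccccc3)C[C@@H]2C(=O)N[C@H]2CCCNC2)n1`, 63%

In a functional assay on HEK293 cells for agonist activity at growth hormone secretagogue receptor type 1 (Homo sapiens), read by HTRF and inositol phosphate accumulation, with a stated time of 90 min, in the presence of a further agent that is not named here (a lower number here means a smaller maximal response, a higher number a larger maximal response), compound 3 gives 63%; compound 2 lies within the usual scatter of that number, and only compound 1 stands beyond it, with a larger maximal response. Within the data shown here, no pair of measured compounds differs in a single place, so no measured step offers a guide for the change at hand. Compound 4, `O=C(N[C@H]1CN(S(=O)(=O)c2ccccc2)C[C@@H]1C(=O)N[C@H]1CCCNC1)c1cc(-c2ccccc2)on1`, has not been measured in this assay. It differs from compound 3 as follows: 5-phenyl-1,2-oxazol-3-yl in place of 4-methyl-1,3-thiazol-2-yl on a carbonyl carbon. Among the measured compounds shown here, with no measured step to rest on, the step of a number 3 percentage points lower from compound 3 to compound 4 (within the scatter) is expected to be small, in no clear direction beyond the scatter. Compound 4 is therefore estimated to give 60% in this assay, with a likely range from 40% to 80%.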

Compound 4, largest response reached (Emax), in percent of the reference or control that the assay uses: 90%
Compound 4: the middle estimate sits 30 percentage points below what was measured; the whole stated range lies below it.
By their numbers in this assay, from the lowest: compounds 3 and 2 (each within the scatter of the next); then compounds 4 and 1 (each within the scatter of the next).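

In this assay, among these compounds, the group on this carbonyl carbon matters: 5-phenyl-1,2-oxazol-3-yl in place of 4-methyl-1,3-thiazol-2-yl brings a number 27 percentage points higher from compound 3 to compound 4 (beyond the scatter) and gives the first single-place step in the set. The entering group adds a six-membered aromatic ring of carbon only, while the counts of hydrogen-bond donors and acceptors stay the same. Nothing measured here explains the rise.

The compounds shown do not separate the added phenyl from the change of the five-membered ring. A 5-methyl-1,2-oxazol-3-yl or 4-phenyl-1,3-thiazol-2-yl group on this carbonyl carbon would address that.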